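The source may report more compounds than this note shows. Statements on the series, on what has been measured and on what is new or still open speak of the compounds shown alone.

Compound 1 `Cc1cc(O)c(C(=O)NCCCc2ccccc2)c(=O)o1` gives 143000 nM
Compound 2 `CCCCCCCCc1c(O)cc(C)oc1=O` gives 145000 nM
Compound 3 `Cc1cc(O)c(C(=O)CCC2CCCCC2)c(=O)o1` gives 117000 nM

All three numbers come from an ADME assay on L929 cells (Mus musculus, culture collection number NCTC 929) for cytotoxicity, read by MTT assay, with a stated time of 72 h; a lower number here means a stronger inhibitor, a higher number a weaker inhibitor. Compound 3 holds the lowest of the three numbers, yet compound 1 and compound 2 both sit within the usual scatter of it, so on these data the three compounds cannot be told apart. This small set already spans an amide, a plain chain and a ketone on the shared core without any step beyond the scatter.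

Compound 4 `CCCCCC(=O)c1c(O)cc(C)oc1=O` is not yet measured. It differs from compound 3 in one place: propyl in place of cyclohexyl on a saturated chain carbon, two bonds along the chain from a carbonyl carbon. Because compound 3 gives 117000 nM and compound 1 and compound 2 sit within the usual scatter of it despite their different side groups, the step from compound 3 to compound 4 is expected to be small, most likely none beyond the scatter, if anything toward a slightly higher number; the expected step is a 1.3-fold higher number from compound 3 to compound 4 (0.11 log units; within the scatter). Compound 4 is therefore estimated at 150000 nM, with a likely range from 75000 nM to 300000 nM.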

Compound 4, half-maximal inhibitory concentration: > 200000 nM
Compound 4: no number, only a limit; the forecaster's own chance of this, stated with the estimate: 10%; middle value at least 1.3-fold (0.12 log units) from the limit.
By their numbers in this assay, from the lowest: compounds 3, 1 and 2 (each within the scatter of the next). At a limit, above all of these: compound 4.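

Among the compounds shown here, this is the first comparison here that changes one place alone: propyl in place of cyclohexyl, on a saturated chain carbon, two bonds along the chain from a carbonyl carbon, gives an at least 1.7-fold higher number from compound 3 to compound 4 (0.23 log units; that floor lies within the scatter) in this assay. That floor does not separate the pair beyond the scatter, yet the change gave no lower number. The true size of the step stays unknown because compound 4 has only a limit, not a number: the limit of > 200000 nM in this assay, at which 1 of the 4 values shown sits.

On these data alone, whether cyclopentyl or an amine at this place would give a number different from that of compound 3 stays open.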